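Extending the ring-nitrogen methyl of compound 2 to 2-hydroxyethyl

A few compounds are considered here, and "the series" means these few. Any claim that something is new, unique, unknown or untested is made for them only; others in the source may bear on it.

Measured compounds:
compound 1, `CC1(C)CC(=O)C2=C(C1)N(C(N)=O)N=C(c1ccccc1)C2`, 26%
compound 2, `CN1N=C(c2ccccc2)CC2=C1CC(C)(C)CC2=O`, 51%

In a functional assay on the whole organism (strain CF) for inhibition, with Mus musculus as the target, at a dose of 25 mg/kg by the oral route (on this read-out lower numbers stand for less inhibition and higher numbers for more inhibition at the one dose given (going by the name of the read-out)), compound 1 gives 26% and compound 2 gives 51%. Compound 2 stands highest of the two numbers, with compound 1 as its nearest neighbour. For the measured compounds named here, the one measured step, a number 25 percentage points higher from compound 1 to compound 2 (beyond the scatter), covers methyl in place of carbamoyl on an amine nitrogen in a ring.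

Compound 3, `CC1(C)CC(=O)C2=C(C1)N(CCO)N=C(c1ccccc1)C2`, is not yet measured in this assay. It differs from compound 2 by hydroxymethyl in place of hydrogen on a saturated chain carbon bound to an amine nitrogen in a ring. The measured step bears only loosely on this change: it swapped the whole group on the ring nitrogen, whereas here the methyl of compound 2 is merely lengthened, with the nitrogen substituent kept. Going by the values given here, no measured pair shows the effect of such a lengthening, so the expectation rests on the scatter alone. For compound 3 the step of a number 6 percentage points lower from compound 2 to compound 3 (within the scatter) is expected to stay within the scatter. The estimate for compound 3 in this assay is 45%, with a range from 20% to 70%.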

Compound 3, a percentage reported as inhibition, in the whole organism at one dose (the size of the read-out at that dose, not a potency): 26%
For compound 3 the middle estimate is 19 percentage points above the measured one; low and high end bracket the measured number.
By their numbers in this assay, from the lowest: compounds 1 and 3 (each within the scatter of the next); then compound 2.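

In this assay, lengthening methyl to 2-hydroxyethyl on the amine nitrogen in a ring is not a neutral change: it gives a number 25 percentage points lower from compound 2 to compound 3 (beyond the scatter), so this position responds even to hydroxymethyl in place of hydrogen on the saturated chain carbon. Carbamoyl and 2-hydroxyethyl are quite different groups, yet the replacement gives no change at the digits printed from compound 1 to compound 3 (within the scatter), so the earlier gain with methyl can no longer be read as a penalty specific to carbamoyl, and among these three compounds only the methyl of compound 2 stands apart. Nothing at hand explains why the added hydroxymethyl lowers the number.

The compounds shown leave open whether the lower number follows from the longer chain or from its terminal hydroxyl, a question that ethyl, n-propyl or 2-methoxyethyl on the same nitrogen would address. They also leave open whether any group on this nitrogen can exceed methyl, and whether a 2-aminoethyl chain or a carboxylic acid at the end of the chain would behave like 2-hydroxyethyl.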